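Moving the pyridine Nitrogen in a Cytotoxicity Series

The compounds below may be only part of what the source reports. "The series", "measured", "known", "first", "only" and "open" are said of these compounds alone.

Four compounds share a common core that carries two side arms, each joined to the core through a double bond. Compound 1 `COc1cc(/C=C2\CN(C)C/C(=C\c3cccnc3)C2=O)cc(OC)c1OC` and compound 3 `COc1cc(/C=C2\CN(C)C/C(=C\c3ccncc3)C2=O)cc(OC)c1OC` carry a trimethoxyphenyl arm on one side, while compound 2 `CN1C/C(=C\c2cccnc2)C(=O)/C(=C/c2ccccc2F)C1` and compound 4 `CN1C/C(=C\c2ccncc2)C(=O)/C(=C/c2ccccc2F)C1` carry a fluorophenyl arm there. The difference between the two cores, from compound 1 to compound 2, is not broken down here.

The measured read-out is an ADME assay on L02 cells (Homo sapiens) for cytotoxicity, read by MTT assay, with a stated time of 24 h; on this read-out lower numbers stand for stronger inhibition and higher numbers for weaker inhibition. In this assay compound 1 gives 14400 nM, compound 2 gives 15900 nM and compound 3 gives 16400 nM. All three values lie close together.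

Going by the values given here, the one counted change in the set is pyridin-4-yl in place of pyridin-3-yl on a double-bonded chain carbon bound to a double-bonded ring carbon. It produces a 1.1-fold higher number from compound 1 to compound 3 (0.06 log units; within the scatter), a step that changes nothing of note. The same change is made in going from compound 2 to compound 4: pyridin-4-yl in place of pyridin-3-yl on a double-bonded chain carbon bound to a double-bonded ring carbon. Both "place" descriptions read the same, so this is the same change, only on a different partner arm.

Because a 1.1-fold higher number from compound 1 to compound 3 (0.06 log units; within the scatter) shows the swap leaving the number essentially unchanged, the step from compound 2 to compound 4 is expected to be a 1.0-fold higher number from compound 2 to compound 4 (0.02 log units; within the scatter). On that basis compound 4 is estimated to give 16500 nM in this assay. The expected range for compound 4 runs from 9000 nM to 30000 nM, reflecting the ordinary spread of such measurements.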

Compound 4, half-maximal inhibitory concentration: 14900 nM
Compound 4: the middle estimate sits 1.1-fold (0.04 log units) above what was measured, within the range that was stated.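

In this assay, putting pyridin-4-yl in place of pyridin-3-yl on a double-bonded chain carbon bound to a double-bonded ring carbon gives a 1.1-fold lower number from compound 2 to compound 4 (0.03 log units; within the scatter), so with the fluorophenyl arm, as with the trimethoxyphenyl arm, the two pyridine forms cannot be told apart in this read-out. Set side by side, the two occurrences of this swap agree as far as the data can tell: the same change on two cores in this assay, a 1.1-fold higher number (0.06 log units; within the scatter) from compound 1 to compound 3 and a 1.1-fold lower number (0.03 log units; within the scatter) from compound 2 to compound 4, 1.2-fold (0.08 log units) apart, within the scatter of two such steps. This shows that, for these two pairs, the swap stays too small to read whichever partner arm is present, but it does not show that a real effect carries over from one core to the other, as neither step rises above the ordinary spread of repeat measurements.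

The compounds shown leave open whether a pyridin-2-yl group, a plain phenyl ring with no nitrogen, or a ring carrying an amine or a carboxylic acid at that same place would give a clearly different number. They also leave open whether the swap would stay this silent with another partner arm, such as a phenyl ring carrying a nitrile.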